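The source may hold more compounds than are shown below. What is called first, only, known or untested is meant among the compounds shown, and "the series" means these compounds.

Working notes on the series. Of the compounds shown here, three have been measured in a functional assay on HTB-54 cells (Homo sapiens) for cytotoxicity, read by MTT assay, with a stated time of 72 h; on this read-out higher numbers stand for weaker inhibition of growth and lower numbers for stronger inhibition of growth. Compound 1, `COc1ccc(OC(=O)Nc2ccc([Se]C#N)cc2)cc1`, gives 48500 nM in this assay. Compound 2, `CCOC(=O)Nc1ccc([Se][Se]c2ccc(NC(=O)OCC)cc2)cc1`, gives 56600 nM in this assay, and compound 3, `O=C(Nc1ccc([Se][Se]c2ccc(NC(=O)Oc3ccc(F)cc3)cc2)cc1)Oc1ccc(F)cc1`, gives 51800 nM. The three numbers sit close together, and the gaps between them lie within the usual scatter of this measurement, so compound 1 cannot be set apart from compound 2 or compound 3 on this read-out; its number is simply one of three that agree.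

Compound 4, `Cc1ccc(OC(=O)Nc2ccc([Se]C#N)cc2)cc1`, has not yet been measured in this assay. It differs from compound 1 in one place: methyl in place of methoxy on an aromatic carbon. Going by the values given here, no measured pair in this set shows what such a change does, so the expectation rests on the flat picture across compounds 1, 2 and 3. The step from compound 1 to compound 4 is expected to be small, with no direction beyond the scatter, as expressed by a 1.0-fold higher number from compound 1 to compound 4 (0.01 log units; within the scatter). Compound 4 is therefore estimated at 50000 nM in this assay, within a range from 20000 nM to 125000 nM.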

Compound 4, concentration for total growth inhibition: 44200 nM
Estimate against measurement, compound 4: 1.1-fold (0.05 log units) above; low and high end bracket the measured number.
By their numbers in this assay, from the lowest: compounds 4, 1, 3 and 2 (each within the scatter of the next).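

Methyl in place of methoxy on an aromatic carbon, para to a large group, is the first single change that can be read in the series, and in this assay it gives a 1.1-fold lower number from compound 1 to compound 4 (0.04 log units; within the scatter) on the core of compound 1. The oxygen and the hydrogen-bond acceptor of methoxy can therefore leave this position with no change in the read-out that stands beyond the scatter. No measurement on hand bears on why the step is so small.

Going by these compounds, whether an amine, a carboxylic acid or a longer alkoxy chain at this position would give a step beyond the scatter remains open. Also open, on these data alone, is whether the same replacement would give a similar step on a core other than that of compound 1.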